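The source may hold more compounds than are shown below. What is called first, only, known or untested is meant among the compounds shown, and "the series" means these compounds.

Compound 1 `C=C1[C@@H](OC(C)=O)C[C@@H]2[C@](C)(CO[Si](C)(C)C(C)(C)C)[C@H](OC(C)=O)CC[C@@]2(C)[C@@H]1C[C@@H](Nc1ccc(OC)cc1)C1=CCOC1=O` carries the silyl-protected alcohol and a 4-methoxyphenyl amine on the shared core, and in a functional assay on KB cells (Homo sapiens) for cytotoxicity, read by sulforhodamine B assay (a lower number here means a stronger inhibitor, a higher number a weaker inhibitor), compound 1 gives 5630 nM, the lowest of the two numbers in hand. Compound 3 `C=C1[C@@H](OC(C)=O)C[C@@H]2[C@](C)(COC=O)[C@H](OC(C)=O)CC[C@@]2(C)[C@@H]1C[C@@H](Nc1cccc2ccccc12)C1=CCOC1=O` gives 32300 nM. Compound 2 `C=C1[C@@H](OC(C)=O)C[C@@H]2[C@](C)(COC=O)[C@H](OC(C)=O)CC[C@@]2(C)[C@@H]1C[C@@H](Nc1ccc(OC)c(OC)c1)C1=CCOC1=O` reaches only the limit of > 50000 nM in this assay, with no number beyond it; this is the limit (the limit of > 50000 nM in this assay, at which 1 of the 3 values shown sits). Going by the values given here, the one step that links measured compounds, an at least 1.5-fold lower number from compound 2 to compound 3 (0.18 log units; that floor lies within the scatter), exchanges the whole aryl group and sits on the formate series, so it says little about a change confined to the 4-methoxyphenyl of compound 1.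

Compound 4 `C=C1[C@@H](OC(C)=O)C[C@@H]2[C@](C)(CO[Si](C)(C)C(C)(C)C)[C@H](OC(C)=O)CC[C@@]2(C)[C@@H]1C[C@@H](Nc1ccc(O)cc1)C1=CCOC1=O` differs from compound 1 only as hydrogen in place of methyl on an oxygen on an aromatic ring. Among the compounds with values here, no measured pair shows a methoxy to hydroxy exchange, so no step of any size in this assay is expected beyond the scatter, and the number for compound 4 is taken close to that of compound 1. The estimate for compound 4 is 6000 nM, with a range from 2500 nM to 16000 nM, meaning an expected step of a 1.1-fold higher number from compound 1 to compound 4 (0.03 log units; within the scatter).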

Compound 4, half-maximal inhibitory concentration: 8350 nM
For compound 4 the middle estimate is 1.4-fold (0.14 log units) below the measured one; low and high end bracket the measured number.
By their numbers in this assay, from the lowest: compounds 1 and 4 (each within the scatter of the next); then compound 3. At a limit, above all of these: compound 2.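

Working from the core of compound 1 with the silyl-protected alcohol held fixed, the exchange of methoxy for hydroxy on the aromatic ring gives a 1.5-fold higher number from compound 1 to compound 4 (0.17 log units; within the scatter) in this assay. Going by these compounds alone, this is the first direct reading at this position, and it shows that the methyl on this oxygen can be lost without a change that stands clear of the scatter, so compound 1 and compound 4 cannot be ranked against each other. Nothing available here gives a cause for this step.

Open, as far as these compounds go, is whether other groups at this place, such as an amine, a carboxylic acid or a longer chain on the oxygen, would move the number beyond the scatter. Also open, from the compounds shown here alone, is whether the same exchange of methoxy for hydroxy would read alike with the formate in place of the silyl-protected alcohol.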